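The source may hold more compounds than are shown below. What is called first, only, known or untested is meant among the compounds shown, and "the series" means these compounds.

Compound 1 `CCNc1cc(C#Cc2ccc(F)s2)nc2c1ncn2[C@H]1[C@H](O)[C@H](O)[C@]2(C(=O)NC)C[C@H]12` — 31%
Compound 2 `CNC(=O)[C@H]1O[C@@H](n2cnc3c(NC)cc(C#Cc4ccc(F)s4)nc32)[C@H](O)[C@@H]1O` — 47%
Compound 3 `CCOC(=O)[C@@]12C[C@@H]1[C@@H](n1cnc3c(NC)cc(C#Cc4ccc(Cl)s4)nc31)[C@H](O)[C@@H]2O` — 17%

Of the compounds shown here, three have been measured in an assay on HEK293 cells for displacement of a labelled ligand from adenosine receptor A1 (Homo sapiens), tested at 10 uM; a lower number here means less inhibition, a higher number more inhibition at the concentration tested (going by the name of the read-out). Compound 1 gives 31%, which is the second highest of the three numbers. Its nearest neighbour is compound 3, which gives 17%, a number lower by a gap that lies beyond the usual scatter. Furthest from it is compound 2, which gives 47%, a number higher by a gap that also lies beyond the scatter. No two of these compounds differ in a single place, so none of the gaps can be tied to one structural change.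

Compound 4 `CNC(=O)[C@@]12C[C@@H]1[C@@H](n1cnc3c(NC)cc(C#Cc4ccc(F)s4)nc31)[C@H](O)[C@@H]2O` has not yet been measured in this assay. It differs from compound 1 in one place: hydrogen in place of methyl on a saturated chain carbon bound to a nitrogen on an aromatic ring. Compounds 2 and 3 both carry the methylamino group, yet they give the highest and the lowest number of the set, so they offer no guidance on the direction of this particular change. The change removes one carbon from a short chain on the shared core, and the account expects a step no larger than the scatter in either direction. For compound 4 the estimated value in this assay is 34%, with a likely range from 16% to 52%, which corresponds to an expected step of a number 3 percentage points higher from compound 1 to compound 4 (within the scatter).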

Compound 4, a percentage reported as inhibition, at one concentration (the size of the read-out at that concentration, not a potency): 20%
Compound 4: the middle estimate sits 14 percentage points above what was measured; low and high end bracket the measured number.
By their numbers in this assay, from the lowest: compounds 3 and 4 (each within the scatter of the next); then compound 1; then compound 2.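

In this assay, within the data shown here, a number 11 percentage points lower from compound 1 to compound 4 (beyond the scatter) is the first step in this set that can be tied to one structural change, since no two of the earlier compounds differed in a single place. It shows that this position on the shared core is not indifferent to chain length: going from ethylamino to methylamino, with hydrogen in place of methyl on a saturated chain carbon bound to a nitrogen on an aromatic ring, is enough by itself to move the number beyond the scatter. The shorter chain gives the lower number here, and the size of the step is modest, so the read-out at this position responds to the removal of one carbon but is not lost with it.

This rests on a single pair, so the compounds shown leave open whether a longer chain such as propylamino would give a higher number, whether a plain amine would give a lower one, and whether the same change would give a similar step on a core carrying other groups. The compounds shown come with no measurement that would explain the step.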